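A few compounds are considered here, and "the series" means these few. Any claim that something is new, unique, unknown or untested is made for them only; others in the source may bear on it.

Notes on the series. In a physicochemical assay for lipophilicity (on this read-out higher numbers stand for higher lipophilicity and lower numbers for lower lipophilicity), compound 1 (`O=C1OCCN1c1cc(C(F)(F)F)ccc1[C@H]1CCOc2cc(S(=O)(=O)Nc3nccs3)ccc21`) gives 2.1. Compound 3 (`Cn1nccc1-c1cc(C(F)(F)F)ccc1[C@@H]1CCOc2cc(S(=O)(=O)Nc3nccs3)ccc21`) gives 2.2, which lies within the scatter of compound 1, so the two cannot be separated on this read-out. Compound 2 (`O=S(=O)(Nc1ncccn1)c1ccc2c(c1)CC[C@@H]2c1ccc(C(F)(F)F)cc1-c1ccc(F)nc1`) gives 3.2, higher than compound 1 by more than the scatter. Going by the values given here, compound 1 thus stands level with compound 3 at the low end of the numbers so far, with compound 2 clear of both.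

Compound 4 (`O=S(=O)(Nc1nccs1)c1ccc2c(c1)OCC[C@@H]2c1ccc(C(F)(F)F)cc1-c1ccc(F)cn1`) has not yet been measured in this assay. It departs from compound 1 at one place: 5-fluoropyridin-2-yl in place of 2-oxo-1,3-oxazolidin-3-yl on an aromatic carbon. Among the compounds with values here, no measured pair isolates this change, so the expectation is indirect. Within the data shown here, compound 2, at 3.2, is the only measured compound carrying a fluorine-bearing pyridine ring, but its core and its sulfonamide partner differ from those of compound 1. That single comparison points upward and leaves the size of the move uncertain. The estimated step is a number 0.90 log units higher from compound 1 to compound 4 (beyond the scatter), upward and expected to exceed the scatter. Compound 4 is expected at 3, with an estimated range of 2.5 to 3.5.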

Compound 4, distribution coefficient: 3.5
Beside the measured number, compound 4's estimate is 0.50 log units below it; the measured number falls inside the stated range.
By their numbers in this assay, from the lowest: compounds 1 and 3 (each within the scatter of the next); then compounds 2 and 4 (each within the scatter of the next).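

Going by these compounds alone, this is the first pair that isolates a single change: on an aromatic carbon ortho to a large group and meta to a trifluoromethyl group, 5-fluoropyridin-2-yl in place of 2-oxo-1,3-oxazolidin-3-yl gives a number 1.40 log units higher from compound 1 to compound 4 (beyond the scatter) in this assay, a large step. The earlier compounds shown here could not separate this position from differences elsewhere in the structure, whereas here the rest of compound 1 stays unchanged and the read-out clearly responds to the group at this one carbon. The change replaces a five-membered non-aromatic ring with 2 hetero atoms by a six-membered aromatic ring with 1 hetero atom, and no measurement available here accounts for the size of the step.

A single pair cannot divide the step among the aromatic ring, the ring nitrogen and the fluorine, so an unsubstituted pyridin-2-yl or a phenyl ring on the same carbon would be the telling comparison. Also open, as far as these compounds go, are where an amine or a carboxylic acid on this carbon would fall on this read-out, and whether a step of this size recurs on a different core.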